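Carrying One Ester Change Across Two Related Compounds

The source may report more compounds than this note shows. Statements on the series, on what has been measured and on what is new or still open speak of the compounds shown alone.

Compound 1 `C=CS(=O)(=O)NC/C=C/c1cc(OC)cc(O)c1C(=O)OC(C)C` and compound 2 `C=CS(=O)(=O)NC/C=C/c1cc(OC)cc(O)c1C(=O)OCC1CCCCC1` share a core and differ in one place: cyclohexylmethyl in place of isopropyl on an oxygen next to a carbonyl group. In a functional assay on THP-1 cells (Homo sapiens) for antiproliferative activity, read by luminescence, with a stated time of 72 h (a lower number here means a stronger inhibitor, a higher number a weaker inhibitor), compound 1 gives 14700 nM, and compound 2 gives 7880 nM, so that a 1.9-fold lower number from compound 1 to compound 2 (0.27 log units; within the scatter). Compound 3 `COc1cc(O)c(C(=O)OC(C)C)c(/C=C/CN2C(=O)C=CC2=O)c1` has a different core; the counted difference from compound 1 is a group of 7 heavy atoms (4 carbon, 1 nitrogen, 2 oxygen; one five-membered non-aromatic ring with 1 hetero atom) in place of a group of 6 heavy atoms (2 carbon, 1 nitrogen, 2 oxygen, 1 sulfur; no ring), on a saturated chain carbon bound to a double-bonded chain carbon, and in this assay compound 3 gives 7320 nM, which means a 2.0-fold lower number from compound 1 to compound 3 (0.30 log units; within the scatter). Compound 4 `COc1cc(O)c(C(=O)OCC2CCCCC2)c(/C=C/CN2C(=O)C=CC2=O)c1` has not been measured yet. It differs from compound 3 by cyclohexylmethyl in place of isopropyl on an oxygen next to a carbonyl group, the same change already seen between the first two compounds, at a place described in identical words. Because that earlier step was a 1.9-fold lower number from compound 1 to compound 2 (0.27 log units; within the scatter), the step for compound 4 is expected to be a 1.6-fold lower number from compound 3 to compound 4 (0.21 log units; within the scatter). The estimate for compound 4 in this assay is 4500 nM, expected to fall between 2000 nM and 9500 nM.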

Compound 4, half-maximal inhibitory concentration: 7710 nM
Compound 4: the middle estimate sits 1.7-fold (0.23 log units) below what was measured, within the range that was stated.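

In this assay, putting cyclohexylmethyl in place of isopropyl on the second core gives a 1.1-fold higher number from compound 3 to compound 4 (0.02 log units; within the scatter), and this step does not differ beyond the scatter from the one on the first core: the same change on two cores in this assay, a 1.9-fold lower number (0.27 log units; within the scatter) from compound 1 to compound 2 and a 1.1-fold higher number (0.02 log units; within the scatter) from compound 3 to compound 4, 2.0-fold (0.29 log units) apart, within the scatter of two such steps. The exchange of the other group, read between the two cyclohexylmethyl esters, gives a 1.0-fold lower number from compound 2 to compound 4 (0.01 log units; within the scatter), and it too agrees with its earlier counterpart: the same change on two cores in this assay, a 2.0-fold lower number (0.30 log units; within the scatter) from compound 1 to compound 3 and a 1.0-fold lower number (0.01 log units; within the scatter) from compound 2 to compound 4, 2.0-fold (0.29 log units) apart, within the scatter of two such steps. The ester change therefore stays small on both cores, but every step lies within the scatter, so this shows no real effect of the change on either core and cannot show that a real effect would carry over.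

The compounds shown leave open what a free carboxylic acid or a benzyl ester would do on either core. They also leave open whether any such change would produce a step beyond the scatter.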